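Amine Ring Variation on the Propoxy Chain

This account rests on a few compounds, and the source may have more. Where it says the series, first, only, none or still open, it means among the compounds named here.

compound 1, `COc1cc2c(Oc3ccc(NC(=O)c4nn(-c5ccccc5C)c(=O)cc4C)cc3F)ccnc2cc1OCCCN1CCCC1`, in a functional assay on NCI-H460 cells (Homo sapiens) for inhibition, read by MTT assay, with a stated time of 72 h; a lower number here means a stronger inhibitor, a higher number a weaker inhibitor: 1590 nM
compound 2, `COc1cc2c(Oc3ccc(NC(=O)c4nn(-c5ccccc5C)c(=O)cc4C)cc3F)ccnc2cc1OCCCN1CCCCC1`, in this assay: 3220 nM

Among the measured compounds shown here, compound 2 gives the highest of the two numbers in this assay; the single measured step, a 2.0-fold higher number from compound 1 to compound 2 (0.31 log units; beyond the scatter), is modest. Compound 3 `COc1cc2c(Oc3ccc(NC(=O)c4nn(-c5ccccc5C)c(=O)cc4C)cc3F)ccnc2cc1OCCCN1CCC(C)CC1` differs from compound 2 by methyl in place of hydrogen on a saturated ring carbon. For the measured compounds named here, no measured step concerns a substituent on that six-membered ring, so the ring-size step from compound 1 to compound 2 bears only loosely, pointing to small effects at this end of the chain. For compound 3 a step of a 1.1-fold higher number from compound 2 to compound 3 (0.04 log units; within the scatter) is expected, inside the scatter, giving an estimated 3500 nM with range 1500 nM to 8000 nM.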

Compound 3, half-maximal inhibitory concentration: 2260 nM
The estimate for compound 3 lay 1.5-fold (0.19 log units) above the measured number; low and high end bracket the measured number.
By their numbers in this assay, from the lowest: compounds 1, 3 and 2 (each within the scatter of the next, the first and the last beyond it).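

In this assay, methyl on a saturated ring carbon, three ring bonds from the ring nitrogen, gives a 1.4-fold lower number from compound 2 to compound 3 (0.15 log units; within the scatter). Set against the pyrrolidin-1-yl end, 4-methylpiperidin-1-yl gives a 1.4-fold higher number from compound 1 to compound 3 (0.15 log units; within the scatter), so neither comparison with this methyl leaves the scatter, while the step from compound 1 to compound 2 does. Nothing available accounts for these numbers.

Still open, from the compounds shown here alone, is how this assay responds to a second ring heteroatom, as in morpholin-4-yl or 4-methylpiperazin-1-yl. Going by these compounds, a hydroxyl on the same ring carbon, or a longer chain to the amine, is equally open.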